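A few compounds are considered here, and "the series" means these few. Any claim that something is new, unique, unknown or untested is made for them only; others in the source may bear on it.

Compounds measured so far:
compound 1, `CN(C)CCNc1nc(-c2ccc(NC(=O)Nc3ccc(F)cc3)cc2)nc2ccsc12`, 350 nM
compound 2, `CN(C)CCNc1nc(-c2ccc(NC(=O)Nc3ccc(Cl)cc3Cl)cc2)nc2ccsc12`, 1320 nM
compound 3, `Cc1ccc(NC(=O)Nc2ccc(-c3nc(NCCN(C)C)c4sccc4n3)cc2)cc1`, 2150 nM

In a functional assay on HT-29 cells (Homo sapiens) for cytotoxicity, read by MTT assay, with a stated time of 72 h (a higher number here means a weaker inhibitor, a lower number a stronger inhibitor), compound 3 shows the highest number of the three. Its nearest neighbour is compound 2, with a 1.6-fold higher number from compound 2 to compound 3 (0.21 log units; within the scatter); its furthest is compound 1, with a 6.1-fold higher number from compound 1 to compound 3 (0.79 log units; beyond the scatter). Compound 4, `CCN(CC)CCCNc1nc(-c2ccc(NC(=O)Nc3ccc(C)cc3)cc2)nc2ccsc12`, differs from compound 3 by (diethylamino)methyl in place of dimethylamino on a saturated chain carbon, two bonds along the chain from a nitrogen on an aromatic ring. Each measured step altered the aryl group of the urea instead: a 3.8-fold higher number from compound 1 to compound 2 (0.58 log units; beyond the scatter) and a 6.1-fold higher number from compound 1 to compound 3 (0.79 log units; beyond the scatter). Among the compounds with values here, no measured step touches the amine chain, so the data give no direct guide to this change. Compound 4 is therefore expected to stay close to compound 3 in this assay, with an estimated step of no change at the digits printed from compound 3 to compound 4 (within the scatter). The estimate for compound 4 is 2150 nM, within a range from 800 nM to 5800 nM.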

Compound 4, half-maximal inhibitory concentration: 1620 nM
Beside the measured number, compound 4's estimate is 1.3-fold (0.12 log units) above it; the range from low to high includes it.
By their numbers in this assay, from the lowest: compound 1; then compounds 2, 4 and 3 (each within the scatter of the next).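

Within the data shown here, compound 4 gives the first reading at the amine chain: in this assay, going from (2-(dimethylamino)ethyl)amino to (3-(diethylamino)propyl)amino gives a 1.3-fold lower number from compound 3 to compound 4 (0.12 log units; within the scatter). Both the chain length and the groups on the terminal nitrogen differ here, yet the two compounds remain within the scatter of each other. Nothing measured bears on why this change leaves the number so little altered. From the compounds shown here alone, the separate contributions of chain length and the ethyl groups remain open, as a 3-(dimethylamino)propyl or 2-(diethylamino)ethyl chain would be needed to divide them. Also open, going by these compounds, are a morpholine in place of the open-chain amine and the same chain on the 4-fluorophenyl urea.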